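Working notes: from compound 2 to compound 3

This account rests on a few compounds, and the source may have more. Where it says the series, first, only, none or still open, it means among the compounds named here.

- compound 1 `COc1ccc(C2CC(Nc3nc4ccc(C)cc4s3)=NN2C(C)=O)cc1`: 37.3 umol/kg
- compound 2 `COc1ccc(C2CC(Nc3nc4ccc(Cl)cc4s3)=NN2C(C)=O)cc1O`: 127 umol/kg

Within the data shown here, in a functional assay on the whole organism (Hindlimb, strain albino) with Mus musculus as the target, in the maximal electroshock model, with a stated time of 0.5 h (a higher number here means that more compound is needed for the effect, a lower number that less compound is needed), compound 2 gives 127 umol/kg, the higher of the two numbers so far. Among the measured compounds shown here, compound 1 lies below it by more than the usual scatter, so compound 2 is the one that needs more compound for the effect.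

The next compound to be measured is compound 3 `CC(=O)N1N=C(Nc2nc3ccc(Cl)cc3s2)CC1c1ccccc1`. It carries phenyl in place of 3-hydroxy-4-methoxyphenyl on a saturated ring carbon. The rest of compound 2 is kept.

For the measured compounds named here, no pair of measured compounds differs in one place only, so this change has no direct precedent. Going by the values given here, the only guide is the value of compound 1, 37.3 umol/kg, which shows that a number well under that of compound 2 is reachable. That guide is weak, and a result near compound 2 would not be surprising. A moderate move to a lower number is expected, with an estimated step of a 2.1-fold lower number from compound 2 to compound 3 (0.33 log units; beyond the scatter). The estimate for compound 3 is 60 umol/kg, with an expected range of 20 umol/kg to 170 umol/kg.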

Compound 3, dose for half-maximal effect: 161 umol/kg
The estimate for compound 3 lay 2.7-fold (0.43 log units) below the measured number; measured number inside the range.
By their numbers in this assay, from the lowest: compound 1; then compounds 2 and 3 (each within the scatter of the next).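

In this assay, among these compounds, phenyl in place of 3-hydroxy-4-methoxyphenyl on a saturated ring carbon gives a 1.3-fold higher number from compound 2 to compound 3 (0.10 log units; within the scatter), the first comparison that changes one place only. The group that leaves carries 1 hydrogen-bond donor and 2 hydrogen-bond acceptors and the group that enters carries none, yet the two numbers stay within the scatter of each other, so at this position the read-out does not separate the two aryl groups, and the hydroxy and methoxy groups together are not required for the effect. No independent measurement bears on why this change leaves the number within the scatter.

From the compounds shown here alone, whether 3-hydroxyphenyl or 4-methoxyphenyl alone would match these two compounds, and whether an amine, a carboxylic acid or a longer chain on this phenyl would move the number beyond the scatter, remains open. Compound 1 differs from compound 2 in more than one place, so the compounds shown tie its value to no single change, and the part played by the other substituents on the shared core remains unresolved.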